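The compounds below may be only part of what the source reports. "The series", "measured", "known", "first", "only" and "open" are said of these compounds alone.

Values in a functional assay on HT-29 cells (Homo sapiens) (on this read-out lower numbers stand for stronger inhibition and higher numbers for weaker inhibition), are as follows.

- Compound 1 (`CCCNC(=O)Nc1ccc(C(C)C)cc1`) gives 76000 nM
- Compound 2 (`CCCNC(=O)Nc1ccc(C(C)(C)C)cc1`) gives 35000 nM
- Compound 3 (`CCNC(=O)Nc1ccc(C(C)CC)cc1`) gives 132000 nM

Compound 1 and compound 3 lie within the scatter of each other, while compound 3 stands beyond the scatter above compound 2. The next compound, compound 4 (`CCCNC(=O)Nc1ccc(C(C)CC)cc1`), has a propyl chain where compound 3 has an ethyl chain. Going by the values given here, the change is methyl in place of hydrogen on a saturated chain carbon, two bonds along the chain from an amide-type nitrogen and no measured step covers this exact place.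

Among the compounds with values here, the only measured step is a 2.2-fold lower number from compound 1 to compound 2 (0.34 log units; beyond the scatter) and it also puts a methyl in place of hydrogen, though at a different place, so it is just a loose guide. Compound 1 and compound 2 share the propyl chain of compound 4, and their values in this assay give a rough window for it. A modest move toward stronger inhibition is therefore expected, and the estimated step is a 2.4-fold lower number from compound 3 to compound 4 (0.38 log units; beyond the scatter) in the same direction as the measured one. For compound 4 the expected value is 55000 nM (estimated range 28000 nM to 105000 nM).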

Compound 4, half-maximal inhibitory concentration: 133000 nM
The estimate for compound 4 lay 2.4-fold (0.38 log units) below the measured number; measured number outside the range, above it.
By their numbers in this assay, from the lowest: compound 2; then compounds 1, 3 and 4 (each within the scatter of the next).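

In this assay, the first direct test of this position shows that propyl in place of ethyl, on a saturated chain carbon two bonds along the chain from an amide-type nitrogen, leaves the number within the scatter: a 1.0-fold higher number from compound 3 to compound 4 (0.00 log units; within the scatter). Among the propyl compounds, the clear difference comes from the group on the aromatic carbon, with sec-butyl in place of tert-butyl giving a 3.8-fold higher number from compound 2 to compound 4 (0.58 log units; beyond the scatter), while the methyl that separates compound 1 from compound 4 gives only a 1.8-fold higher number from compound 1 to compound 4 (0.24 log units; within the scatter). Methyl in place of hydrogen therefore has a readable effect at one place and none at this one, yet the two steps cannot be told apart: the same change on two cores in this assay, a 2.2-fold lower number (0.34 log units; beyond the scatter) from compound 1 to compound 2 and a 1.0-fold higher number (0.00 log units; within the scatter) from compound 3 to compound 4, 2.2-fold (0.34 log units) apart, within the scatter of two such steps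

Going by these compounds, whether a longer chain such as butyl, or a chain ending in an amine or a carboxylic acid, would shift the number at this position remains open. On these data alone, it is also open whether ethyl and propyl would stay alike with tert-butyl in place of sec-butyl on the aromatic carbon.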